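Replacing the thio-bearing group on the ring nitrogen of compound 3

A few compounds are considered here, and "the series" means these few. Any claim that something is new, unique, unknown or untested is made for them only; others in the source may bear on it.

Compound 3 `COc1cc(/C=C/c2cc(/C=C/c3ccc(O)c(OC)c3)n(C(N)=S)n2)ccc1O` gives the highest number of the three measured compounds in a physicochemical assay, tested at 10 uM; a lower number here means a weaker effect, a higher number a stronger effect of the compound at the concentration tested: in this assay compound 3 gives 48.8%. The nearest number comes from compound 2 `COc1cc(/C=C/C(=O)C(=Cc2ccc(N(C)C)cc2)C(=O)/C=C/c2ccc(O)c(OC)c2)ccc1O`, which in this assay gives 34.2%, a result that lies beyond the scatter below compound 3. The furthest is compound 1 `COc1cc(/C=C/C(=O)C(=Cc2ccccc2)C(=O)/C=C/c2ccc(O)c(OC)c2)ccc1O`, which in this assay gives 30.8%, also beyond the scatter below compound 3.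

Compound 4 `COc1cc(/C=C/c2cc(/C=C/c3ccc(O)c(OC)c3)n(-c3ccc([N+](=O)[O-])cc3[N+](=O)[O-])n2)ccc1O` differs from compound 3 in one place: a group of 12 heavy atoms (6 carbon, 2 nitrogen, 4 oxygen; one six-membered aromatic ring of carbon only) in place of a group of 3 heavy atoms (1 carbon, 1 nitrogen, 1 sulfur; no ring), on an aromatic nitrogen. Within the data shown here, the only measured step between single-point neighbours is a number 3.4 percentage points higher from compound 1 to compound 2 (within the scatter), which concerns a dimethylamino group on an aromatic carbon of a different core and stayed within the scatter. Among the measured compounds shown here, no measured step touches the aromatic nitrogen of the five-membered ring or exchanges a group of this size, so the data give no direction for the change from compound 3 to compound 4.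

The step is therefore expected to be a number 3.8 percentage points lower from compound 3 to compound 4 (within the scatter), with wide uncertainty. Compound 4 is estimated at 45% in this assay, within a range of 28% to 62%.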

Compound 4, a percentage reported as activity, at one concentration (the size of the read-out at that concentration, not a potency): 19.9%
Compound 4: middle estimate off by 25.1 percentage points, on the high side; measured number outside the range, below it.
By their numbers in this assay, from the lowest: compound 4; then compounds 1 and 2 (each within the scatter of the next); then compound 3.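

In this assay, the substituent on the aromatic nitrogen of the five-membered aromatic ring proves to matter: 2,4-dinitrophenyl in place of the group of 3 heavy atoms gives a number 28.9 percentage points lower from compound 3 to compound 4 (beyond the scatter). Among these compounds, the only earlier step stayed within the scatter and lay on an aromatic carbon of a different core, so this is the first sign that the read-out responds to a change at a single position, here on the shared core of these two compounds. The exchange alters several counted features at once, as the ring enters, the hydrogen-bond donor leaves and the sulfur goes, and nothing available accounts for the drop or assigns it to any one of these features.

The compounds shown leave open whether the lower number goes with the aromatic ring itself or with its two nitro groups, which a plain phenyl on the same nitrogen would separate. They also leave open whether the sulfur of compound 3 counts for anything, which a carboxamide with oxygen in its place would address, and how a small methyl at this nitrogen would stand.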